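The compounds below may be only part of what the source reports. "The series", "measured", "known", "first", "only" and "open" are said of these compounds alone.

In a functional assay on cells (Cancer cell lines, Homo sapiens) for inhibition (on this read-out higher numbers stand for weaker inhibition of growth and lower numbers for stronger inhibition of growth), compound 1 (`CN1C/C(=C\c2cccs2)C(O)/C(=C/c2cccs2)C1`) gives 85800 nM as its value. Compound 2 (`Cc1ccc(/C=C2\CN(C)CC3=C2N=C(S)NC3c2ccc(C)cc2)cc1`) gives 37100 nM and compound 3 (`CN1C/C(=C\c2cccs2)C2=NN(C)C(c3cccs3)C2C1`) gives 79200 nM as theirs. Compound 3 therefore stands level with compound 1 within the usual scatter of repeated measurements, so those two cannot be told apart. Compound 2 stands apart from both with a lower number, beyond that scatter, which means stronger inhibition of growth.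

Compound 4 (`CN1C/C(=C\c2cccs2)C2=NN(c3ccccc3)C(c3cccs3)C2C1`) differs from compound 3 in one place: phenyl in place of methyl on an amine nitrogen in a ring. Among the measured compounds shown here, no two measured compounds differ in only one place, so no measured step shows what such a swap does. For the measured compounds named here, the only guide is the narrow span of the three values, with compound 2 at 37100 nM on one end and compound 1 at 85800 nM on the other. A small move towards stronger inhibition is expected, and it may not clear the scatter. The estimated step is a 1.6-fold lower number from compound 3 to compound 4 (0.20 log units; within the scatter) and no large jump is expected. In this assay compound 4 is estimated at 50000 nM with 18000 nM to 100000 nM as the expected range.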

Compound 4, concentration for 50% growth inhibition: 3800 nM
The estimate for compound 4 lay 13-fold (1.12 log units) above the measured number, outside the stated range (below it).
By their numbers in this assay, from the lowest: compound 4; then compound 2; then compounds 3 and 1 (each within the scatter of the next).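

In this assay, putting phenyl in place of methyl on this amine nitrogen in a ring gives a 21-fold lower number from compound 3 to compound 4 (1.32 log units; beyond the scatter), which moves towards stronger inhibition of growth. Among the compounds shown here, this is the first direct sign that the group on this nitrogen matters a great deal: the earlier compounds included no pair differing in only one place, so they could not isolate the effect of any single position. The change replaces 1 heavy atom with 6 and adds a six-membered aromatic ring of carbon only, while neither group has any hydrogen-bond donors or acceptors, but no measurement shown here explains why the step is so large.

As far as these compounds go, it remains open whether the aromatic ring itself matters or whether a larger carbon group of another shape would serve equally well, and a cyclohexyl ring or a straight butyl chain on this nitrogen would help separate those two readings. A single step on one core also cannot show whether phenyl would have a similar effect on the other cores shown, or whether a pyridyl ring could take its place.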